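Fluoro to chloro on the pendant aryl ring

The compounds below may be only part of what the source reports. "The series", "measured", "known", "first", "only" and "open" are said of these compounds alone.

Compound 2 `O=C1c2ccc(F)cc2C(=O)N1c1nc(-c2ccc(F)cc2)cs1` and compound 1 `O=C1c2ccc(F)cc2C(=O)N1c1nc(-c2ccccc2)cs1` share one core and differ only in a fluoro for a hydrogen on an aromatic carbon. In a functional assay on PC-3 cells (Homo sapiens) for antiproliferative activity, read by MTT assay, with a stated time of 48 h (on this read-out lower numbers stand for stronger inhibition and higher numbers for weaker inhibition), compound 1 gives 40200 nM and compound 2 gives 39500 nM; the two numbers sit within the scatter of each other, so neither stands apart from the other. The step of a 1.0-fold lower number from compound 1 to compound 2 (0.01 log units; within the scatter) is the only measured one in the series. Compound 3 `O=C1c2ccc(F)cc2C(=O)N1c1nc(-c2ccc(Cl)cc2)cs1` carries chloro in place of fluoro on an aromatic carbon. Within the data shown here, this is a second exchange at the same aromatic carbon, and the one exchange already seen there, a 1.0-fold lower number from compound 1 to compound 2 (0.01 log units; within the scatter), moved nothing beyond the scatter. With no larger shift in the series to point either way, the step of a 1.1-fold lower number from compound 2 to compound 3 (0.05 log units; within the scatter) is expected to stay within the scatter. Compound 3 is therefore estimated at 35000 nM in this assay, with a range from 15000 nM to 85000 nM.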

Compound 3, half-maximal inhibitory concentration: 38000 nM
For compound 3 the middle estimate is 1.1-fold (0.04 log units) below the measured one; the measured number falls inside the stated range.
By their numbers in this assay, from the lowest: compounds 3, 2 and 1 (each within the scatter of the next).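

In this assay, the exchange of fluoro for chloro at this aromatic carbon gives a 1.0-fold lower number from compound 2 to compound 3 (0.02 log units; within the scatter), and the exchange of hydrogen for chloro at the same carbon gives a 1.1-fold lower number from compound 1 to compound 3 (0.02 log units; within the scatter). This carbon, para to a large group, has now carried hydrogen, fluoro and chloro with no step beyond the scatter, so the flat reading no longer rests on a single exchange and 4-chlorophenyl reads the same as 4-fluorophenyl. No supporting data bear on why this position gives such flat readings.

Still open, going by these compounds, is whether a group other than a single halogen at this carbon, such as an amine, a carboxylic acid or a longer chain, would move the number beyond the scatter. On these data alone, the three compounds also share the same fluoro on the core, so the effect of changing that part remains unknown.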